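This account rests on a few compounds, and the source may have more. Where it says the series, first, only, none or still open, it means among the compounds named here.

Compound 1 `Cc1ccc(-n2nc(-c3ccc4ccccc4c3)nc2N2C(=O)COC23C=CC(=O)C=C3)cc1`: 150 nM
Compound 2 `O=C1C=CC2(C=C1)OCC(=O)N2c1nc(-c2ccc3ccccc3c2)nn1-c1ccc2ccccc2c1`: 210 nM
Compound 3 `Cc1ccc(-n2nc(-c3ccc4ccccc4c3)nc2N2C(=O)C(C)OC23C=CC(=O)C=C3)cc1`: 530 nM

In a functional assay on HeLa cells (Homo sapiens) for antiproliferative activity, with a stated time of 5 days (a higher number here means a weaker inhibitor, a lower number a stronger inhibitor), compound 1 gives 150 nM, which places it at the stronger end of this small set, level with compound 2 within the scatter. Compound 3 lies clearly higher. Compound 4 `Cc1ccc(-n2nc(-c3cccc4ccccc34)nc2N2C(=O)COC23C=CC(=O)C=C3)cc1` has the same atoms as compound 1, joined differently: naphthalen-1-yl in place of naphthalen-2-yl on an aromatic carbon.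

Among the measured compounds shown here, no measured step tests this change directly. The closest evidence is a 1.4-fold higher number from compound 1 to compound 2 (0.15 log units; within the scatter), which shows that naphthalen-2-yl can replace 4-methylphenyl on an aromatic nitrogen without a real shift in the number. The other measured step, a 3.5-fold higher number from compound 1 to compound 3 (0.55 log units; beyond the scatter), shows that a single methyl on a saturated ring carbon can produce a modest rise. A small edit to this series can therefore matter or not, and a modest rise is the reasonable expectation here, although no change beyond the scatter remains possible.

The expected step is a 2.0-fold higher number from compound 1 to compound 4 (0.30 log units; within the scatter). Compound 4 is estimated at 300 nM, with an expected range from 100 nM to 900 nM.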

Compound 4, half-maximal inhibitory concentration: 140 nM
Compound 4: the middle estimate sits 2.1-fold (0.33 log units) above what was measured; measured number inside the range.
By their numbers in this assay, from the lowest: compounds 4, 1 and 2 (each within the scatter of the next); then compound 3.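

In this assay, putting naphthalen-1-yl in place of naphthalen-2-yl on this aromatic carbon gives a 1.1-fold lower number from compound 1 to compound 4 (0.03 log units; within the scatter) and no real shift. Among the compounds shown here, the earlier steps concerned an aromatic nitrogen and a saturated ring carbon, so this is the first reading at this position: here, the point at which the naphthalene is joined can change without moving the number beyond the scatter. Nothing at hand accounts for the two naphthalene isomers reading alike.

The compounds shown leave open whether this aromatic carbon accepts a group other than a naphthalene, such as a plain phenyl, a cyclohexyl or a pyridine ring. They also leave open whether a naphthalene carrying a methoxy group or an amine would keep the number in the same range.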